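Swapping the Amine Ring Substituent: Expected Solubility of Compound 3

This account rests on a few compounds, and the source may have more. Where it says the series, first, only, none or still open, it means among the compounds named here.

Of the compounds shown here, two sharing one core have been measured in a physicochemical assay for solubility, measured as kinetic solubility; on this read-out lower numbers stand for lower solubility and higher numbers for higher solubility. Compound 1 `O=C(Nc1ccnnc1)c1cc(N2CCCC2)ccc1OCc1ccccc1` carries a pyrrolidin-1-yl group on an aromatic carbon and gives 35000 nM. Compound 2 `O=C(Nc1ccnnc1)c1cc(N2CCC(CO)CC2)ccc1OCc1ccccc1` carries a 4-(hydroxymethyl)piperidin-1-yl group in that place and gives 323000 nM. For the measured compounds named here, the single measured step, a 9.2-fold higher number from compound 1 to compound 2 (0.97 log units; beyond the scatter), leaves compound 2 as the higher of the two numbers, with compound 1 as its only neighbour.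

Compound 3 `O=C(Nc1ccnnc1)c1cc(N2C[C@H]3COC[C@H]3C2)ccc1OCc1ccccc1` has not yet been measured. Relative to compound 2 it shows the change a group of 8 heavy atoms (6 carbon, 1 nitrogen, 1 oxygen; 2 five-membered non-aromatic rings with 1 hetero atom each) in place of a group of 8 heavy atoms (6 carbon, 1 nitrogen, 1 oxygen; one six-membered non-aromatic ring with 1 hetero atom), on an aromatic carbon — the six-membered ring bearing a hydroxymethyl gives way to two fused five-membered rings, and the hydrogen-bond donor present in compound 2 is absent.

Going by the values given here, only the step from compound 1 to compound 2 bears on this change, and it runs in the opposite sense: a donor-free group was exchanged for one with a donor, and the number rose well beyond the scatter. Since compound 3 returns to a donor-free group, the expected direction is downward, a 3.2-fold lower number from compound 2 to compound 3 (0.51 log units; beyond the scatter), though a smaller fall than the rise seen for compound 2 seems likely, as the new group keeps two acceptors. In this assay compound 3 is therefore estimated at 100000 nM, with a range from 30000 nM to 300000 nM.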

Compound 3, solubility: 57000 nM
Compound 3: middle estimate off by 1.8-fold (0.24 log units), on the high side, within the range that was stated.
By their numbers in this assay, from the lowest: compounds 1 and 3 (each within the scatter of the next); then compound 2.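

This change at the position para to the benzyloxy group gives a 5.7-fold lower number from compound 2 to compound 3 (0.75 log units; beyond the scatter) in this assay, so replacing 4-(hydroxymethyl)piperidin-1-yl with the fused pair of five-membered rings does not preserve the high number of compound 2, even though the heavy-atom and hydrogen-bond-acceptor counts stay the same. The other comparison gives a 1.6-fold higher number from compound 1 to compound 3 (0.21 log units; within the scatter), so the larger fused group, with its ring oxygen and two defined stereocentres, cannot be told apart from the smaller pyrrolidin-1-yl group on this read-out. Among these three compounds, the one group that carries a hydrogen-bond donor also gives the only number that stands clear of the others, although three compounds are too few to establish a rule.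

The step from compound 2 to compound 3 changes the ring system and removes the donor at the same time, so a 4-(methoxymethyl)piperidin-1-yl group, which keeps the six-membered ring and has an ether in place of the alcohol, would be the kind of comparison that could separate the two changes. Nothing at hand gives a measured reason for the size of either step.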